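The compounds below may be only part of what the source reports. "The series", "measured", "known", "first", "only" and "open" are said of these compounds alone.

Compound 1 `COc1ccc(-c2[nH]c(-c3ccc(Cl)cc3)cc2-c2cn(-c3ccc(Cl)cc3)nc2-c2ccc(C)cc2)cc1` is tested in a functional assay on the whole organism (strain Wistar albino) for inhibition, with Rattus norvegicus as the target, read by paw edema, with stated times of 1 h and 3 h, at a dose of 0.32 mmol/kg by the intraperitoneal route (a lower number here means less inhibition, a higher number more inhibition at the dose given (going by the name of the read-out)), where compound 1 gives 21.3%, the upper of two numbers that lie within the scatter of each other. Compound 2 `COc1ccc(-c2nn(-c3ccc(Cl)cc3)cc2-c2cc(-c3ccc(Cl)cc3)[nH]c2-c2ccc(OC)cc2)cc1` gives 20.7%, and the step of a number 0.6 percentage points lower from compound 1 to compound 2 (within the scatter) is within the scatter. Compound 3 `COc1ccc(-c2[nH]c(-c3ccc(Cl)cc3)cc2-c2cn(-c3ccc(S(N)(=O)=O)cc3)nc2-c2ccc(C)cc2)cc1` differs from compound 1 by sulfamoyl in place of chloro on an aromatic carbon. Within the data shown here, no measured step touches the chloro, so the change has no direct precedent here; the only step seen swapped methoxy for methyl and stayed within the scatter. Compound 3 is therefore expected to show a number 3.7 percentage points higher from compound 1 to compound 3 (within the scatter), with wide uncertainty. Compound 3 is estimated at 25%, between 10% and 45%.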

Compound 3, a percentage reported as inhibition, in the whole organism at one dose (the size of the read-out at that dose, not a potency): 34.2%
Compound 3: middle estimate off by 9.2 percentage points, on the low side; low and high end bracket the measured number.
By their numbers in this assay, from the lowest: compounds 2 and 1 (each within the scatter of the next); then compound 3.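

Swapping the 4-chlorophenyl for 4-sulfamoylphenyl gives, in this assay, a number 12.9 percentage points higher from compound 1 to compound 3 (beyond the scatter), the only step so far that clears the scatter. The number therefore responds to what this position, on the aromatic ring and para to a large group, carries, which the methoxy for methyl step could not show. No measurement here explains the rise.

Open, as far as these compounds go, is how a carboxylic acid or an amine at this position would read. Also open, from the compounds shown here alone, is whether sulfamoyl in place of chloro gives a similar step on compound 2.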